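Swapping an Ethyl for 2-Fluorophenyl on a Ring Nitrogen

The source may report more compounds than this note shows. Statements on the series, on what has been measured and on what is new or still open speak of the compounds shown alone.

Of the compounds shown here, three have so far been tested in a functional assay on SJSA-1 cells (Homo sapiens) for inhibition, read by CCK-8 assay, with a stated time of 72 h, tested at 1 uM; a lower number here means less inhibition, a higher number more inhibition at the concentration tested (going by the name of the read-out). Compound 1 `COc1ccccc1N1C(=O)CSC1C(=O)NCCCCc1ccccc1` gives 14%. Compound 2 `CCN1C(=O)CSC1c1cccc(C(=O)NCCCCc2ccccc2)c1` gives 3%, the lowest of the three numbers, standing beyond the scatter below compound 1 and further still below compound 3 `O=C(NCCCCc1ccccc1)c1cccc(C2OCC(=O)N2c2cccc(F)c2)c1`, which gives 32%. Compound 4 `O=C(NCCCCc1ccccc1)c1cccc(C2SCC(=O)N2c2ccccc2F)c1` has not yet been measured; it differs from compound 2 in one place: 2-fluorophenyl in place of ethyl on an amide-type nitrogen in a ring. Among the measured compounds shown here, no single-change step between two measured compounds is known here, so the size of this step rests on judgement rather than on a measured precedent. Compound 4 is expected to give 18%, with a range from 5% to 35%. This estimate means an expected rise a number 15 percentage points higher from compound 2 to compound 4 (beyond the scatter), modest but beyond the scatter.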

Compound 4, a percentage reported as inhibition, at one concentration (the size of the read-out at that concentration, not a potency): 80%
Compound 4: middle estimate off by 62 percentage points, on the low side; measured number outside the range, above it.
By their numbers in this assay, from the lowest: compound 2; then compound 1; then compound 3; then compound 4.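

In this assay, 2-fluorophenyl in place of ethyl on this amide-type nitrogen in a ring gives a number 77 percentage points higher from compound 2 to compound 4 (beyond the scatter) as the first single-change step available in this set. It shows that the group at this one position can, with the rest of the molecule unchanged, have a large effect on inhibition at the concentration tested. Nothing available explains the size of this step.

The compounds shown leave open whether the rise comes from the phenyl ring or its fluorine, which a plain phenyl group on that nitrogen could separate. Also open, on these data alone, is whether a benzyl group or a longer chain such as butyl there would behave more like ethyl or like 2-fluorophenyl.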